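Working notes on a single-concentration series

A few compounds are considered here, and "the series" means these few. Any claim that something is new, unique, unknown or untested is made for them only; others in the source may bear on it.

Measured so far:
compound 1 `COc1cc(Nc2ncccc2-c2nc(Nc3cc(OC)ccc3OC)n[nH]2)cc(OC)c1`: 20%
compound 2 `COc1cc(Nc2ncccc2-c2nc(-c3cccc(OC)c3)n[nH]2)cc(OC)c1`: "not determined" (no result reported)
compound 3 `O=C1CCCN1CCCNc1ncccc1-c1n[nH]c(Nc2ccc3c(c2)OCCO3)n1`: "not determined" (no result reported)

In a functional assay on A-431 cells (Homo sapiens), tested at 0.1 uM (a higher number here means more inhibition at the concentration tested (going by the name of the read-out), a lower number less inhibition), compound 1 gives 20%. For compound 2 this assay reports "not determined" (no result reported). Compound 3 likewise stands without a single number, "not determined" (no result reported), so it is one of two compounds here with no result, beside one measured compound with a low read-out.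

Compound 4 `COc1ccc(CNc2ncccc2-c2n[nH]c(Nc3ccc4c(c3)OCCO4)n2)cc1` differs from compound 3 by 4-methoxyphenyl in place of 2-(2-oxopyrrolidin-1-yl)ethyl on a saturated chain carbon bound to a nitrogen on an aromatic ring. Among the compounds with values here, no step between measured compounds is available, so for this change in this assay no direction is assigned, and a shift is expected to stay within the scatter. Compound 4 is expected to give about 20%, estimated between 0% and 50%. Within the data shown here, this rests only on compound 1 at 20%, the sole number in the set.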

Compound 4, a percentage reported as inhibition, at one concentration (the size of the read-out at that concentration, not a potency): 30%
For compound 4 the middle estimate is 10 percentage points below the measured one; measured number inside the range.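

In this assay compound 4 gives 30% while compound 3 has no single number, so no step can be read between them. No evidence bears on this result. The compounds shown leave open whether exchanging 3-(2-oxopyrrolidin-1-yl)propyl for 4-methoxybenzyl changes inhibition.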